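Methyl in place of pyridinyl on a triazole, mouse potency expected unchanged

The compounds below may be only part of what the source reports. "The series", "measured", "known", "first", "only" and "open" are said of these compounds alone.

Compound 1 `Cc1nnc(CN(C)C)n1-c1ccccc1C(=O)c1ccccc1Cl` is one of two measured compounds. In a functional assay on the whole organism (strain CF-1) for inhibition, with Mus musculus as the target (on this read-out lower numbers stand for an effect already at smaller amounts and higher numbers for an effect only at larger amounts of compound), compound 1 gives only a limit, > 100 mg/kg. Compound 2 `CN(C)Cc1nnc(-c2ccncc2)n1-c1ccc(Cl)cc1C(=O)c1ccccc1Cl` likewise gives only a limit in this assay, > 100 mg/kg. Compound 2 thus stands at the same place as the other value, namely (the limit of > 100 mg/kg in this assay, at which 2 of the 2 values shown sit). Compound 3 `Cc1nnc(CN(C)C)n1-c1ccc(Cl)cc1C(=O)c1ccccc1Cl` differs from compound 2 by methyl in place of pyridin-4-yl on an aromatic carbon. With both known values sitting at that limit, no step beyond the scatter is expected; the estimated step that the limit leaves unreadable from compound 2 to compound 3 is none. Compound 3 is therefore expected near 150 mg/kg, within a range from 60 mg/kg to 400 mg/kg, most likely reported again as a limit.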

Compound 3, dose for half-maximal effect: 50 mg/kg
The estimate for compound 3 lay 3.0-fold (0.48 log units) above the measured number; the measured number lies below the stated range.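

In this assay, compound 3 is the only one of the three compounds shown to give a number rather than a limit. Methyl in place of pyridin-4-yl gives an at least 2.0-fold lower number from compound 2 to compound 3 (0.30 log units; that floor lies within the scatter), and chloro in place of hydrogen gives an at least 2.0-fold lower number from compound 1 to compound 3 (0.30 log units; that floor lies within the scatter). Each step is only a floor, because its starting compound sits at a limit: the limit of > 100 mg/kg in this assay, at which 2 of the 3 values shown sit.

On these data alone, how far either step truly reaches stays open. Also open, as far as these compounds go, is whether an ethyl or a phenyl group on this aromatic carbon of the five-membered ring would likewise give a number rather than a limit.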